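The source may hold more compounds than are shown below. What is called first, only, known or untested is meant among the compounds shown, and "the series" means these compounds.

Measured compounds:
compound 1 `COc1ccc(/C=C\C(=O)O)c(OCc2cn(-c3ccccc3C(=O)N3CCC(O)C3)nn2)c1CC=C(C)C`: 13400 nM
compound 2 `COc1ccc(/C=C\C(=O)O)c(OCc2cn(-c3ccccc3I)nn2)c1CC=C(C)C`: "not determined" (no result reported)
compound 3 `COc1ccc(-n2cc(COc3c(/C=C\C(=O)O)ccc(OC)c3CC=C(C)C)nn2)cc1`: "not determined" (no result reported)

In a functional assay on T47D cells (Homo sapiens) for cytotoxicity, read by MTT assay, with a stated time of 24 h (a higher number here means a weaker inhibitor, a lower number a stronger inhibitor), compound 1 gives 13400 nM, a weak result. For compound 2 the entry is "not determined" (no result reported), so no number stands for it. For the measured compounds named here, compound 3 likewise has no number in this assay: its entry reads "not determined" (no result reported), and it shares this position with compound 2, the one further compound without a single number. Compound 3 therefore cannot be ranked against compound 1 on the values shown.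

The unmeasured compound 4 `COc1ccc(/C=C\C(=O)O)c(OCc2cn(-c3ccccc3)nn2)c1CC=C(C)C` differs from compound 3 in one place: hydrogen in place of methoxy on an aromatic carbon. No step from compound 3 to compound 4 is shown, and compound 3 itself carries no number, so the size of this step in this assay can only be guessed; a change of this kind is expected to stay within the scatter, in no firm direction. With only compound 1 and its 13400 nM as a measured anchor on the shared core, compound 4 is expected to give about 15000 nM in this assay, within a range of 4000 nM to 60000 nM.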

Compound 4, half-maximal inhibitory concentration: 34100 nM
For compound 4 the middle estimate is 2.3-fold (0.36 log units) below the measured one, and the stated range covers the measured number.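

In this assay, hydrogen in place of (3-hydroxypyrrolidin-1-yl)carbonyl on an aromatic carbon gives a 2.5-fold higher number from compound 1 to compound 4 (0.41 log units; beyond the scatter), a modest loss of strength that lies beyond the usual scatter and shows that the number responds to the group at this carbon. The steps that involve compound 2 or compound 3, including the change from 4-methoxyphenyl to phenyl, cannot be read, as neither compound has a number. Nothing available explains why the number moves.

The compounds shown leave open whether the gain belongs to the hydroxyl of the (3-hydroxypyrrolidin-1-yl)carbonyl group or to its carbonyl. They also leave open how a simple amine or a carboxylic acid on this aromatic carbon would compare, and whether any such group could bring the number well below that of compound 1.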